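The source may report more compounds than this note shows. Statements on the series, on what has been measured and on what is new or still open speak of the compounds shown alone.

Compound 1 `O=C(Nc1nnc(-c2ccc(Cl)cc2)s1)c1ccccc1` is an amide built on a shared core. In a functional assay on the whole organism (integument) for inhibition, with Chilo suppressalis as the target, read by scintillation counting, with a stated time of 72 h (on this read-out higher numbers stand for weaker inhibition and lower numbers for stronger inhibition), compound 1 gives only > 5010 nM, which is a limit of the assay rather than a number, and this limit is the point (the limit of > 5010 nM in this assay, at which 1 of the 2 values shown sits). A second compound, compound 2 `O=C(Nc1nnc(-c2ccc(Cl)cc2)s1)c1c(Cl)cccc1Cl`, differs from compound 1 in the benzamide ring; in this assay compound 2 gives 380 nM. The untested compound 3 `O=C(Nc1nnc(-c2ccc(Cl)cc2)s1)c1ccccc1I` is reached from compound 1 by a single change, (iodo in place of hydrogen on an aromatic carbon), in words: iodo in place of hydrogen on an aromatic carbon. Among the measured compounds shown here, no measured step between two compounds that differ in one place is available here, so the size of this step rests on the two values above. The step from compound 1 to compound 3 is expected to be an at least 3.3-fold lower number from compound 1 to compound 3 (0.52 log units; beyond the scatter), toward stronger inhibition. Compound 3 is estimated to give 1500 nM in this assay, within a range from 400 nM to 6000 nM.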

Compound 3, half-maximal inhibitory concentration: > 5010 nM
Compound 3: a limit, no number; the forecaster's own chance of this, stated with the estimate: 25%; at least 3.3-fold (0.52 log units) between middle value and limit.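

In this assay compound 3 gives > 5010 nM, which is a limit of the assay and not a number. Among the compounds shown here, compound 1 also stands at a limit, so no step from compound 1 to compound 3 can be read: the limit of > 5010 nM in this assay, at which 2 of the 3 values shown sit. Going by these compounds, whether iodo in place of hydrogen changes inhibition at all, and by how much, stays open.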